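A few compounds are considered here, and "the series" means these few. Any claim that something is new, unique, unknown or untested is made for them only; others in the source may bear on it.

Values in a functional assay on NIH3T3 cells (Mus musculus); on this read-out lower numbers stand for an effect already at smaller amounts and higher numbers for an effect only at larger amounts of compound:
- compound 1 `CCCCCCC#Cc1cc(C#N)ccc1COC(c1ccc(C#N)cc1)c1cncn1C`: > 0.1 nM (a limit)
- compound 2 `Cn1cncc1C(OCc1ccc(C#N)cc1/C=C/c1ccc([N+](=O)[O-])cc1)c1ccc(C#N)cc1`: 2.24 nM
- compound 3 `Cn1cncc1C(OCc1ccc(C#N)cc1-c1ccc(C#N)cc1)c1ccc(C#N)cc1`: < 0.1 nM (a limit)

Compound 3 has only a limit, < 0.1 nM, so it offers no exact starting number. Compound 4 `Cn1cncc1C(OCc1ccc(C#N)cc1C#CC(C)(C)C)c1ccc(C#N)cc1` has not yet been measured. In it, 3,3-dimethylbut-1-yn-1-yl takes the place of 4-cyanophenyl on an aromatic carbon: 3,3-dimethylbut-1-yn-1-yl in place of 4-cyanophenyl on an aromatic carbon.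

Compound 1 is the closest guide, as its oct-1-yn-1-yl also holds a triple bond. The step involving it is a number no higher from compound 1 to compound 3 (the limit leaves the size open). Changes at this place can be large, as shown by an at least 22-fold lower number from compound 2 to compound 3 (1.35 log units; beyond the scatter). A moderate rise is therefore expected, an at least 3.0-fold higher number from compound 3 to compound 4 (0.47 log units; beyond the scatter). Compound 4 is estimated at 0.3 nM, with an expected range of 0.06 nM to 1.5 nM.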

Compound 4, half-maximal effective concentration: 76.9 nM
Beside the measured number, compound 4's estimate is 260-fold (2.41 log units) below it, and the stated range ends below it.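

In this assay, swapping the group at this position for 3,3-dimethylbut-1-yn-1-yl gives an at least 760-fold higher number from compound 3 to compound 4 (2.88 log units; beyond the scatter), and it also gives a 34-fold higher number from compound 2 to compound 4 (1.54 log units; beyond the scatter). With the rest of the molecule unchanged, this group therefore needs much larger amounts of compound for an effect than either 4-cyanophenyl or 2-(4-nitrophenyl)ethenyl. Nothing shown here explains the size of these steps.

As far as these compounds go, compound 1 has only a limit, so its step to compound 4 cannot be read, and the effect of hexyl against tert-butyl on the triple bond stays open. Whether an amine or a carboxylic acid at the end of that triple bond would bring the number down is also unknown.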